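The source may hold more compounds than are shown below. What is called first, only, known or untested is meant among the compounds shown, and "the series" means these compounds.

Measured so far:
compound 1 `O=C1C=C(Cl)C(O)(c2ccc(Cl)cc2)N1C1CC1`, 4000 nM in an assay on cell membranes for displacement of a labelled ligand from Cholecystokinin receptor type A (Rattus norvegicus), read by CCK-8 assay, with a stated time of 2 h; a lower number here means a stronger inhibitor, a higher number a weaker inhibitor
compound 2 `O=C1C=C(Cl)C(O)(c2ccccc2)N1C1CCCC1`, 360 nM

Among the compounds with values here, compound 2 holds the lowest of the two numbers in this assay; the only other measured compound, compound 1, gives a higher number, a gap beyond the scatter. Compound 1 and compound 2 differ in two places at once, so no single change can be read from that pair.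

Compound 3 `O=C1C=C(Cl)C(O)(c2ccc(Cl)cc2)N1C1CCCC1` is not yet measured. It differs from compound 2 by chloro in place of hydrogen on an aromatic carbon. Within the data shown here, no measured pair shows this change on its own, so its direction in this assay is open; compound 1 carries the same chloro together with a different ring on the nitrogen, which leaves the two contributions entangled. The expected step is therefore small, within or just beyond the scatter, with a wide range either way.

The estimate for compound 3 is 600 nM, between 150 nM and 2500 nM, the expected step of a 1.7-fold higher number from compound 2 to compound 3 (0.22 log units; within the scatter).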

Compound 3, half-maximal inhibitory concentration: 2500 nM
The estimate for compound 3 lay 4.2-fold (0.62 log units) below the measured number, and the stated range covers the measured number.
By their numbers in this assay, from the lowest: compound 2; then compounds 3 and 1 (each within the scatter of the next).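

In this assay, chloro in place of hydrogen on an aromatic carbon, para to a large group, can now be read on its own, and it weakens binding (a 6.9-fold higher number from compound 2 to compound 3 (0.84 log units; beyond the scatter)). With the chloro kept, cyclopentyl in place of cyclopropyl on the amide-type nitrogen separates nothing (a 1.6-fold lower number from compound 1 to compound 3 (0.20 log units; within the scatter)), so this pair gives no preference between the two rings. The chloro step rests on one pair, with cyclopentyl on the nitrogen, and cannot be extended to the cyclopropyl compounds.

From the compounds shown here alone, whether a fluoro or a methoxy group at the same aromatic position would also raise the number remains open, as does any ring on the nitrogen other than these two. Nothing available on this series explains the loss seen with the chloro.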